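This account rests on a few compounds, and the source may have more. Where it says the series, first, only, none or still open, it means among the compounds named here.

Two compounds of one shared core are in hand. Compound 1 `C=CCn1c(SCC(=O)Nc2ccc(/C(C)=N/O)cc2)nnc1-c1ccccc1` gives 61% in a functional assay on the whole organism (strain albino) for inhibition, with Rattus norvegicus as the target, read by paw edema, with stated times of 30 min and 1 h, at a dose of 0.28 mmol/kg by the oral route; a lower number here means less inhibition, a higher number more inhibition at the dose given (going by the name of the read-out). Compound 2 `CCn1c(SCC(=O)Nc2ccc(/C(C)=N/O)cc2)nnc1-c1ccc(OC)cc1` gives 54% in this assay; its number stands alongside that of compound 1, the two lying within the usual scatter of each other. Compound 3 `CCn1c(SCC(=O)Nc2ccc(/C(C)=N/O)cc2)nnc1-c1ccccc1` is not yet measured and differs from compound 2 in one place: hydrogen in place of methoxy on an aromatic carbon. For the measured compounds named here, no step between measured compounds tells how such a change acts, so the step from compound 2 to compound 3 is expected to stay within the scatter, a number 3 percentage points higher from compound 2 to compound 3 (within the scatter). Compound 3 is therefore expected to give about 57%, somewhere between 45% and 68%.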

Compound 3, a percentage reported as inhibition, in the whole organism at one dose (the size of the read-out at that dose, not a potency): 54%
Beside the measured number, compound 3's estimate is 3 percentage points above it; the range from low to high includes it.
By their numbers in this assay, from the lowest: compounds 2, 3 and 1 (each within the scatter of the next).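

In this assay, the step of no change at the digits printed from compound 2 to compound 3 (within the scatter) shows that hydrogen can take the place of methoxy on this aromatic carbon without a change beyond the scatter. The step of a number 7 percentage points lower from compound 1 to compound 3 (within the scatter) adds that methyl in place of vinyl on the saturated chain carbon bound to an aromatic nitrogen also leaves the number within the scatter. Nothing available explains either result.

Going by these compounds, whether an amine or a carboxylic acid on that aromatic carbon, or a longer chain on the aromatic nitrogen, would shift the number remains open.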